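Swapping Methylamino for Azido: Expected Oral Exposure

The source may report more compounds than this note shows. Statements on the series, on what has been measured and on what is new or still open speak of the compounds shown alone.

Measured so far:
Compound 1, `CNc1ccc(C(=O)O)c(O)c1`: 130000 ng.h/mL
Compound 2, `Nc1cc(O)c(C(=O)O)cc1F`: 10000 ng.h/mL

Two compounds have been run in an ADME assay on the whole organism (Mus musculus, strain CD-1) for pharmacokinetics, read by LC-MS, with a stated time of 24 h, at a dose of 25 mg/kg by the oral route; on this read-out lower numbers stand for lower exposure and higher numbers for higher exposure at the dose given. Compound 1 gives 130000 ng.h/mL, the higher of the two numbers. Compound 2 gives 10000 ng.h/mL, a number well below that of compound 1 and beyond the usual scatter, so compound 1 stands as the better exposed of the pair on the data in hand.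

The next compound, compound 3, `[N-]=[N+]=Nc1ccc(C(=O)O)c(O)c1`, keeps the core of compound 1 and changes a single group: azido in place of methylamino on an aromatic carbon. Going by the values given here, no pair of measured compounds shows what this exact swap does, so the expectation rests on compound 1 alone and on the general experience that a change of one small group at the edge of a molecule rarely moves exposure by a very large amount.

The step is expected to be a moderate loss, a 2.2-fold lower number from compound 1 to compound 3 (0.34 log units; beyond the scatter), close to the edge of the scatter rather than far beyond it. Compound 3 is therefore estimated at 60000 ng.h/mL in this assay, with a likely range from 20000 ng.h/mL to 150000 ng.h/mL.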

Compound 3, area under the concentration-time curve: 900000 ng.h/mL
The estimate for compound 3 lay 15-fold (1.18 log units) below the measured number, and the stated range ends below it.
By their numbers in this assay, from the lowest: compound 2; then compound 1; then compound 3.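

In this assay, the group on the aromatic carbon para to a carboxy group and meta to a hydroxy group turns out to have a large say in oral exposure: azido in place of methylamino gives a 6.9-fold higher number from compound 1 to compound 3 (0.84 log units; beyond the scatter) for this swap alone. The earlier compounds shown here gave no view of how far a change at this place could move the number, and this pair shows that it can move it upward, well past the usual scatter, while the rest of the core of compound 1 stays untouched. Methylamino counts a hydrogen-bond donor and azido counts none, but no measurement at hand ties the rise to that difference or to any other feature of the two groups.

A single pair leaves open whether the gain belongs to azido itself or would come with any group at this place that carries no hydrogen on its nitrogen or has no such donor at all. Groups such as dimethylamino, methoxy or nitrile at the same carbon would help to tell these two readings apart.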